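The source may hold more compounds than are shown below. What is called first, only, known or untested is meant among the compounds shown, and "the series" means these compounds.

Measured in an ADME assay on microsomes from liver (Mus musculus) for metabolic stability, with a stated time of 10 min; on this read-out higher numbers stand for a more stable compound and lower numbers for a less stable compound:
Compound 1 `O=C([C@H]1CC[C@H](c2nnn[nH]2)CC1)N1CC[C@](c2ccc(C(F)(C(F)(F)F)C(F)(F)F)cc2)(S(=O)(=O)c2ccc(F)cc2)C1`: 73%
Compound 2 `NC(=O)[C@H]1CC[C@H](C(=O)N2CC[C@](c3ccc(C(F)(C(F)(F)F)C(F)(F)F)cc3)(S(=O)(=O)c3ccc(F)cc3)C2)CC1`: 100%
Compound 3 `O=C(C1CCS(=O)(=O)C1)N1CC[C@](c2ccc(C(F)(C(F)(F)F)C(F)(F)F)cc2)(S(=O)(=O)c2ccc(F)cc2)C1`: 78%; 96% (2 entries)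

Compound 2, at 100%, holds the higher of the two single numbers in this assay. Compound 1 lies below it, and compound 3 has two entries rather than one number. Compound 4 `O=C(C1CCS(=O)(=O)CC1)N1CC[C@](c2ccc(C(F)(C(F)(F)F)C(F)(F)F)cc2)(S(=O)(=O)c2ccc(F)cc2)C1`, not yet measured, differs from compound 2 in one place: 1,1-dioxothian-4-yl in place of 4-carbamoylcyclohexyl on a carbonyl carbon. In words, 1,1-dioxothian-4-yl stands in place of 4-carbamoylcyclohexyl on a carbonyl carbon.

Among the compounds with values here, only one measured step is available, a number 27 percentage points higher from compound 1 to compound 2 (beyond the scatter). It is a different exchange, so it indicates only the size a change in this part of the molecule can reach. Compound 3 carries the group most like the entering one, and its results are the several entries of compound 3 in this assay, 78%; 96% (2 entries). Compound 2, at 100%, leaves little room upward, so a modest fall is expected, probably smaller than the step to compound 2 from compound 1. The expected change is a number 15 percentage points lower from compound 2 to compound 4 (beyond the scatter). For compound 4 the estimate is 85%, with an expected range from 68% to 100%.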

Compound 4, percent of the compound remaining: 96%
Estimate against measurement, compound 4: 11 percentage points below, and the stated range covers the measured number.
By their numbers in this assay, from the lowest: compound 1; then compounds 4 and 2 (each within the scatter of the next).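

In this assay, the exchange on the carbonyl carbon gives a number 4 percentage points lower from compound 2 to compound 4 (within the scatter), which shows that the carbamoyl group and its cyclohexane ring are not needed for a high number here: a ring with 1 hetero atom and 0 hydrogen-bond donors serves as well. Set against the tetrazole-bearing group, the same 1,1-dioxothian-4-yl gives a number 23 percentage points higher from compound 1 to compound 4 (beyond the scatter), so two different replacements of 4-(1H-tetrazol-5-yl)cyclohexyl now stand clear of compound 1. Compound 3, with the group most like 1,1-dioxothian-4-yl, has an upper entry that matches the number of compound 4, though its entries are spread: the several entries of compound 3 in this assay, 78%; 96% (2 entries)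

Still open, on these data alone, is whether a carboxylic acid or an amine in place of the carbamoyl group would keep the number in this assay. An open-chain alkyl sulfone on the carbonyl carbon is equally untested by these compounds.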